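Alkenyl Chain in Place of Benzyl on the Ring Nitrogen

The compounds below may be only part of what the source reports. "The series", "measured", "known", "first", "only" and "open" are said of these compounds alone.

For the measured compounds named here, compound 2 `c1ccc(CN2CCC3(CC2)OCCc2c3cnn2-c2ccccc2)cc1` is one of two compounds measured in an assay for displacement of a labelled ligand from Sigma non-opioid intracellular receptor 1 (Cavia porcellus), read by scintillation counting, with a stated time of 180 min; on this read-out lower numbers stand for stronger inhibition and higher numbers for weaker inhibition. In this assay compound 2 gives 1.71 nM. Compound 1 `COC1Cc2c(cnn2-c2ccccc2)C2(CCN(CCCCc3ccccc3)CC2)O1`, which carries a different substituent on the ring nitrogen, gives 3.2 nM in this assay, and these two numbers lie within the usual scatter of each other, so neither compound stands apart from the other on this evidence. Compound 3 `C=C(C)CCN1CCC2(CC1)OCCc1c2cnn1-c1ccccc1` has not yet been measured. It differs from compound 2 in one place: 2-methylprop-2-en-1-yl in place of phenyl on a saturated chain carbon bound to an amine nitrogen in a ring. Going by the values given here, no step between measured compounds covers this change. Because compound 1 gives 3.2 nM with a different nitrogen substituent, the substituent on the ring nitrogen appears to be variable without a large change, and only a modest weakening is expected, of about a 4.7-fold higher number from compound 2 to compound 3 (0.67 log units; beyond the scatter). Compound 3 is expected to give 8 nM in this assay, with a range from 2 nM to 40 nM.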

Compound 3, inhibition constant: 0.97 nM
The estimate for compound 3 lay 8.2-fold (0.92 log units) above the measured number, and the stated range ends above it.
By their numbers in this assay, from the lowest: compounds 3, 2 and 1 (each within the scatter of the next, the first and the last beyond it).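

In this assay, the exchange of benzyl for 3-methylbut-3-en-1-yl on the ring nitrogen gives a 1.8-fold lower number from compound 2 to compound 3 (0.25 log units; within the scatter), so this step does not separate the two compounds. Compound 1 differs from compound 2 in more than one place and could not isolate this position, whereas this pair shows that, with the core unchanged, a group with no ring can take the place of benzyl and stay within the scatter. No available evidence bears on why the two groups read alike.

The compounds shown leave open whether the double bond in the chain matters, as neither the saturated 3-methylbutyl group nor a cyclohexylmethyl group is among them. They also leave open whether a chain ending in an amine or a carboxylic acid would be accepted at this position.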